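Carbamoyl for hydroxy on a second purine core

The source may report more compounds than this note shows. Statements on the series, on what has been measured and on what is new or still open speak of the compounds shown alone.

Of the compounds shown here, three have been tested in a functional assay on the whole organism (Tail, strain ICR) with Mus musculus as the target, in the tail flick test, with a stated time of 30 min, at a dose of 25 umol/kg by the oral route (a higher number here means a stronger effect of the compound at the dose given, a lower number a weaker effect), and a fourth awaits measurement. Compound 1 `O=C(CN(c1nc(Cl)nc2[nH]cnc12)C1CC1)N[C@@H](CO)C(=O)O` gives 38.7% in this assay. Compound 2 `NC(=O)C[C@H](NC(=O)CN(c1nc(Cl)nc2[nH]cnc12)C1CC1)C(=O)O` carries one change relative to compound 1, namely (carbamoyl in place of hydroxy on a saturated chain carbon, two bonds along the chain from an amide-type nitrogen and a carbonyl carbon), and in this assay compound 2 gives 29.7%; the step is a number 9 percentage points lower from compound 1 to compound 2 (within the scatter). Compound 3 `O=C(CN(c1ncnc2c1ncn2C1CCCCO1)C1CC1)N[C@@H](CO)C(=O)OCc1ccccc1` rests on a different core; how that core differs from the core of compound 1 is not broken down here. In this assay compound 3 gives 27.8%, which lies within the scatter of compound 2 and is lower than the number for compound 1.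

Compound 4 `NC(=O)C[C@H](NC(=O)CN(c1ncnc2c1ncn2C1CCCCO1)C1CC1)C(=O)OCc1ccccc1` stands to compound 3 as compound 2 stands to compound 1: the change is carbamoyl in place of hydroxy on a saturated chain carbon, two bonds along the chain from an amide-type nitrogen and a carbonyl carbon, made at the same place in the chain. For the measured compounds named here, since the only measured instance of this change, the one from compound 1 to compound 2, moved the read-out by no more than the scatter, the expectation for the second instance is a step of comparable size, a number 6.8 percentage points lower from compound 3 to compound 4 (within the scatter), with some allowance for a different core. On that basis compound 4 is estimated to give 21% in this assay, with an expected range from 8% to 34%.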

Compound 4, a percentage reported as activity, at one dose (the size of the read-out at that dose, not a potency): 34.5%
For compound 4 the middle estimate is 13.5 percentage points below the measured one; measured number above the stated range.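

On the second core, carbamoyl in place of hydroxy gives, in this assay, a number 6.7 percentage points higher from compound 3 to compound 4 (within the scatter). For the compounds shown here, each of the two steps stays within the scatter when read alone, but set side by side they do not agree: the same change on two cores in this assay, a number 9 percentage points lower (within the scatter) from compound 1 to compound 2 and a number 6.7 percentage points higher (within the scatter) from compound 3 to compound 4, 15.7 percentage points apart, beyond the scatter of two such steps This shows that, in this series, the step read on the core of compound 1 cannot simply be carried to the core of compound 3, neither in size nor in direction, although it does not show that the change by itself raises or lowers the read-out on either core, and with only two pairs, it does not show which feature separating the two cores goes with the gap between the steps.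

The compounds shown leave open how an amine or a longer chain, such as carbamoylethyl, would read in place of hydroxy on the saturated chain carbon, and whether either would behave alike on both cores. They also leave open whether the same change on a third core would follow the step seen on the core of compound 1, the step seen on the core of compound 3, or neither.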